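Chain length and growth inhibition in a hydroxamic acid series

This account rests on a few compounds, and the source may have more. Where it says the series, first, only, none or still open, it means among the compounds named here.

Measured so far:
Compound 1, `C#CCN(C)Cc1ccc(NC(=O)CCCCCC(=O)NO)cc1`: > 10000 nM
Compound 2, `C#CCN(C)Cc1ccc(NC(=O)CCCCCCC(=O)NO)cc1`: 1510 nM

Compound 1 reaches only a limit of a functional assay on DU-145 cells (Homo sapiens) for inhibition, read by MTT assay, with a stated time of 48 h; a higher number here means a weaker inhibitor of growth, a lower number a stronger inhibitor of growth; in that assay compound 1 gives > 10000 nM, which is a limit rather than a number. Compound 2, in this assay, gives 1510 nM, the only actual number shown, and it is the stronger of the two, since the step of an at least 6.6-fold lower number from compound 1 to compound 2 (0.82 log units; beyond the scatter) lies beyond the scatter.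

Compound 3, `C#CCN(C)Cc1ccc(NC(=O)CCCCCCCC(=O)NO)cc1`, has not yet been measured. It differs from compound 2 by the change ((hydroxycarbamoyl)methyl in place of hydroxycarbamoyl on a saturated chain carbon, six bonds along the chain from a carbonyl carbon). This is the same kind of lengthening that separates compound 2 from compound 1, and that step brought a clear gain. Whether a second lengthening continues the gain cannot be read from two compounds, one of them a limit. The expectation for compound 3 is therefore a value near that of compound 2, with the step of a 1.0-fold lower number from compound 2 to compound 3 (0.00 log units; within the scatter) expected to stay within the scatter. Compound 3 is estimated at 1500 nM, with a range from 500 nM to 5000 nM.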

Compound 3, concentration for 50% growth inhibition: 3400 nM
For compound 3 the middle estimate is 2.3-fold (0.36 log units) below the measured one, within the range that was stated.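

In this assay, the gain from the first lengthening does not carry on to the next: the change from hydroxycarbamoyl to (hydroxycarbamoyl)methyl at this place now gives a 2.3-fold higher number from compound 2 to compound 3 (0.35 log units; beyond the scatter) and so costs some growth inhibition. Compound 3 still compares well with the shortest chain, with an at least 2.9-fold lower number from compound 1 to compound 3 (0.46 log units; beyond the scatter) printed for that pair, so among these three compounds growth inhibition is strongest at the middle chain length, in compound 2. The size of the step from compound 1 has no upper end because compound 1 gives only a limit: the limit of > 10000 nM in this assay, at which 1 of the 3 values shown sits.

Going by these compounds, whether a still longer chain, such as 4-(hydroxycarbamoyl)butyl at this place, would lose more growth inhibition remains open. So does whether a carboxylic acid in place of the hydroxycarbamoyl end would keep any of it.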